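This account rests on a few compounds, and the source may have more. Where it says the series, first, only, none or still open, it means among the compounds named here.

Compound 1 `COc1cc(C(=O)c2sc(-c3ccc(C)cc3)cc2N)cc(OC)c1OC` and compound 2 `COc1cc(C(=O)c2sc(-c3cccc([N+](=O)[O-])c3)cc2N)cc(OC)c1OC` share one core and differ only in the aromatic ring attached to it. In a functional assay on MOLT-4 cells (Homo sapiens) for antiproliferative activity (on this read-out lower numbers stand for stronger inhibition and higher numbers for weaker inhibition), compound 1 gives 16 nM, while compound 2 gives 7.5 nM, the lowest of the two numbers; the step of a 2.1-fold lower number from compound 1 to compound 2 (0.33 log units; beyond the scatter) is modest yet beyond the scatter. Compound 3 `COc1cc(C(=O)c2sc(-c3ccc([N+](=O)[O-])cc3)cc2N)cc(OC)c1OC` is the next case: 4-nitrophenyl in place of 3-nitrophenyl on an aromatic carbon. Going by the values given here, only the step from compound 1 to compound 2 bears on this, and it exchanged one group for another rather than shifting the same group, so it gives no direction. The step of a 1.2-fold higher number from compound 2 to compound 3 (0.08 log units; within the scatter) is therefore expected to stay within the scatter, and compound 3 is estimated at 9 nM, with a range from 3 nM to 30 nM.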

Compound 3, half-maximal inhibitory concentration: 110 nM
The estimate for compound 3 lay 12-fold (1.09 log units) below the measured number; measured number above the stated range.
By their numbers in this assay, from the lowest: compound 2; then compound 1; then compound 3.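

Moving the nitro group, with the same atoms joined differently, gives a 15-fold higher number from compound 2 to compound 3 (1.17 log units; beyond the scatter) and shows that the choice between 3-nitrophenyl and 4-nitrophenyl at this place on the shared core matters far more than the earlier exchange suggested. Nitro is also not simply better than methyl, since a 6.9-fold higher number from compound 1 to compound 3 (0.84 log units; beyond the scatter) runs opposite to the gain seen with 3-nitrophenyl. No measurement at hand explains this difference. Still open, as far as these compounds go, is whether an amine or a carboxylic acid in place of the nitro group of 3-nitrophenyl would keep the low number of compound 2.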